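The source may hold more compounds than are shown below. What is called first, only, known or untested is meant among the compounds shown, and "the series" means these compounds.

Measured so far:
compound 1 `O=[N+]([O-])c1cn2c(n1)OC[C@@H](OCc1ccc(-c3cc(C(F)(F)F)ccn3)s1)C2`: > 128000 nM
compound 2 `Cn1c(CO[C@@H]2COc3nc([N+](=O)[O-])cn3C2)cnc1-c1ccc(C(F)(F)F)cc1`: > 128000 nM
compound 3 `Cn1c(CO[C@@H]2COc3nc([N+](=O)[O-])cn3C2)cnc1-c1ccc(C#N)cc1`: > 128000 nM

In an ADME assay on Vero cells (Chlorocebus sabaeus) for cytotoxicity, with a stated time of 72 h (on this read-out lower numbers stand for stronger inhibition and higher numbers for weaker inhibition), compound 1 gives > 128000 nM, which is a limit of the assay and not a number. Compound 2 gives > 128000 nM in this assay, again a limit. Compound 3 gives > 128000 nM in this assay, also a limit. Compound 3 thus stands only at a limit, as do the two other values shown; all three sit at the same point, (the limit of > 128000 nM in this assay, at which 3 of the 3 values shown sit). Among the measured compounds shown here, the one step among measured compounds, cyano in place of trifluoromethyl on an aromatic carbon, reads a step that the two limits leave unreadable from compound 2 to compound 3 and gives no size.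

Compound 4 `Cn1c(CO[C@@H]2COc3nc([N+](=O)[O-])cn3C2)cnc1-c1ccc(F)cc1` differs from compound 3 by fluoro in place of cyano on an aromatic carbon. For the measured compounds named here, no measured step bears on this change with a readable size, and every value shown is a limit. In this assay the step from compound 3 to compound 4 is therefore expected to be a number no higher from compound 3 to compound 4 (the limit leaves the size open), nothing readable beyond the scatter. Compound 4 is estimated at 128000 nM in this assay, within 64000 nM to 300000 nM, most likely reported once more as a limit.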

Compound 4, half-maximal inhibitory concentration: > 128000 nM
Compound 4: only a limit was reported; the forecaster's own chance of this, stated with the estimate: 85%; the middle value sits exactly at the limit.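

Neither the step from compound 3 to compound 4 nor the step from compound 2 to compound 4 can be read in this assay, as every value is a limit: the limit of > 128000 nM in this assay, at which 4 of the 4 values shown sit.

The compounds shown leave open whether cyano, fluoro and trifluoromethyl differ at all in this assay, and what a change that brings the values off the limit would look like.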